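Shortening the amine-bearing chain in a bornyl ester series

The source may report more compounds than this note shows. Statements on the series, on what has been measured and on what is new or still open speak of the compounds shown alone.

Compound 2 `CC1(C)[C@H]2CC[C@]1(C)[C@H](OC(=O)CCN1CCCC1)C2` holds the highest of the two numbers measured in an ADME assay on MDCK cells (Canis lupus familiaris) for cytotoxicity, read by MTT assay, with a stated time of 48 h (on this read-out lower numbers stand for higher toxicity in this test and higher numbers for lower toxicity in this test), where compound 2 gives 125000 nM. Its nearest neighbour is compound 1 `CC1(C)[C@H]2CC[C@]1(C)[C@H](OC(=O)CCN1CCNCC1)C2`, which in this assay gives 12600 nM; the step of a 9.9-fold higher number from compound 1 to compound 2 (1.00 log units; beyond the scatter) covers the exchange of the amine on the chain. Compound 3 `CC1(C)[C@H]2CC[C@]1(C)[C@H](OC(=O)CN1CCCC1)C2` is not yet measured. It differs from compound 2 by pyrrolidin-1-yl in place of (pyrrolidin-1-yl)methyl on a saturated chain carbon bound to a carbonyl carbon. For the measured compounds named here, the one measured step concerns a different change, the swap of one amine for another, and no measured pair speaks to shortening the chain between the carbonyl and the amine. The expectation therefore rests on compound 2 alone, and compound 3 is estimated to give a number in this assay close to that of compound 2, a step of a 1.3-fold lower number from compound 2 to compound 3 (0.10 log units; within the scatter) within the scatter. Compound 3 is expected to give 100000 nM, with a range from 40000 nM to 250000 nM.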

Compound 3, half-maximal cytotoxic concentration: 302000 nM
Estimate against measurement, compound 3: 3.0-fold (0.48 log units) below, and the stated range ends below it.
By their numbers in this assay, from the lowest: compound 1; then compound 2; then compound 3.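

Replacing (pyrrolidin-1-yl)methyl with pyrrolidin-1-yl on a saturated chain carbon bound to a carbonyl carbon gives in this assay a 2.4-fold higher number from compound 2 to compound 3 (0.38 log units; beyond the scatter) and so shows that this position also affects the read-out, which the earlier pair, differing only in the amine, could not show. Set against the compound carrying (piperazin-1-yl)methyl at this place, the change gives a 24-fold higher number from compound 1 to compound 3 (1.38 log units; beyond the scatter) and spans the widest gap in the series, towards lower toxicity in this test. Nothing at hand explains why the number rises with this change.

From the compounds shown here alone, it remains open whether piperazin-1-yl would respond in the same way on the shorter chain, and whether a longer chain would reverse the direction seen here. Going by these compounds, an open-chain amine such as diethylamino, or an amide in place of the ester, also remains untested within this account.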